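Halogen swap on the aryl triazole: bromo to chloro

A few compounds are considered here, and "the series" means these few. Any claim that something is new, unique, unknown or untested is made for them only; others in the source may bear on it.

Measured so far:
- compound 1, `CC1(C)[C@H]2CC[C@]1(C)N(Cc1cn(-c3ccccc3Br)nn1)C(=O)C2`: 140 nM
- compound 2, `CC1(C)[C@H]2CC[C@]1(C)N(Cc1cn(-c3ccccc3F)nn1)C(=O)C2`: 300 nM

In a functional assay on OVCAR-3 cells (Homo sapiens) for inhibition, read by MTT assay, with a stated time of 24 h (on this read-out lower numbers stand for stronger inhibition and higher numbers for weaker inhibition), compound 1 gives the lower of the two numbers shown, and compound 2 sits above it by the step of a 2.1-fold higher number from compound 1 to compound 2 (0.33 log units; beyond the scatter), a change that comes from swapping one halogen for another on an aromatic carbon. Compound 3, `CC1(C)[C@H]2CC[C@]1(C)N(Cc1cn(-c3ccccc3Cl)nn1)C(=O)C2`, is not yet measured; it differs from compound 1 by chloro in place of bromo on an aromatic carbon. Among the compounds with values here, the only measured step that bears on it is the one from compound 1 to compound 2, a modest step. Chloro and bromo are closer in kind than bromo and fluoro, so the expected change in this assay is smaller, most likely within the scatter, perhaps a slightly higher number. The estimate for compound 3 is therefore 190 nM, in the range 100 nM to 400 nM, an expected step of a 1.4-fold higher number from compound 1 to compound 3 (0.13 log units; within the scatter).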

Compound 3, half-maximal inhibitory concentration: 40 nM
Compound 3: the middle estimate sits 4.8-fold (0.68 log units) above what was measured; measured number below the stated range.
By their numbers in this assay, from the lowest: compound 3; then compound 1; then compound 2.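

Changing the halogen on this aromatic carbon does not move the number in one direction: in this assay, chloro gives a 3.5-fold lower number from compound 1 to compound 3 (0.54 log units; beyond the scatter), and it also gives a 7.5-fold lower number from compound 2 to compound 3 (0.88 log units; beyond the scatter). Compound 1 alone suggested that the heavier halogen was the better one, but with both steps beyond the scatter, compound 3 now ranks as the most potent of the three, and the chloro group outperforms both the lighter fluoro and the heavier bromo at this position. No measurement here explains why chloro stands out from the other two halogens.

The compounds shown leave open how an iodo group, a methyl group or an amine on this same carbon would compare with chloro. They also leave open whether the same order of the three halogens would hold in other cell lines.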